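The source may hold more compounds than are shown below. What is called first, only, known or untested is meant among the compounds shown, and "the series" means these compounds.

Measured so far:
compound 1, `COc1ccc(-c2nc(C)c(C(=O)CSc3nc(-c4ccc(OC)cc4)c(C#N)c(=O)[nH]3)s2)cc1`: 32.6%
compound 2, `Cc1nc(-c2ccccc2)sc1C(=O)CSc1nc(-c2ccccc2)c(C#N)c(=O)[nH]1`: 77.5%

Both compounds were tested in a functional assay on U-87MG ATCC cells for antiproliferative activity against U-87 MG (Homo sapiens), read by MTT assay, with a stated time of 48 h, tested at 50 uM; on this read-out lower numbers stand for a stronger effect and higher numbers for a weaker effect at the one concentration tested. Compound 2 gives 77.5%, the highest of the two numbers and therefore the weaker effect. Its nearest neighbour, compound 1, gives 32.6%, a number well beyond the scatter below it. Within the data shown here, no single-change step between these two is recorded, so their values can only be set side by side.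

Compound 3, `COc1ccc(-c2nc(C)c(C(=O)CSc3nc(-c4ccccc4)c(C#N)c(=O)[nH]3)s2)cc1`, has not been measured yet. It is reached from compound 2 by one change: methoxy in place of hydrogen on an aromatic carbon. Compound 1 also carries methoxy at such a position and stands far lower than compound 2, which is the only hint available. Among the measured compounds shown here, on that basis a drop from compound 2 to compound 3 is expected, beyond the scatter but smaller than the gap between compound 2 and compound 1, because compound 1 gives 32.6% while carrying more than the one change that separates compound 2 from compound 3. The expected step is a number 22.5 percentage points lower from compound 2 to compound 3 (beyond the scatter). For compound 3 the estimate is 55%, within a range from 35% to 75%.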

Compound 3, a percentage reported as activity, at one concentration (the size of the read-out at that concentration, not a potency): 72.5%
Compound 3: the middle estimate sits 17.5 percentage points below what was measured; measured number inside the range.
By their numbers in this assay, from the lowest: compound 1; then compounds 3 and 2 (each within the scatter of the next).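

In this assay, swapping phenyl for 4-methoxyphenyl, with methoxy in place of hydrogen para to a large group, gives a number 5 percentage points lower from compound 2 to compound 3 (within the scatter), so this single change, taken alone, does not shift the read-out beyond ordinary variation. The large effect appears with the methoxy on the other aromatic ring: with hydrogen in its place, the result is a number 39.9 percentage points higher from compound 1 to compound 3 (beyond the scatter), which shows that, with the first methoxy present, the second one accounts for nearly all of the stronger effect seen in compound 1. No measurement is at hand that would explain either step.

The compounds shown never carry methoxy on that other ring without the first methoxy also being present, so it remains open whether the second methoxy would give the same drop by itself or needs the first one alongside it. Also open, from the compounds shown here alone, is how this assay would respond to a different group para to a large group, such as an amine, a carboxylic acid or a longer chain like butoxy, and whether any of these would move the number where methoxy does not.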